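Moving a hydroxyl group on two inactive pyridine analogues

A few compounds are considered here, and "the series" means these few. Any claim that something is new, unique, unknown or untested is made for them only; others in the source may bear on it.

The study begins with two compounds that share the same core. Compound 1 `Oc1ccc(-c2cc(-c3cccs3)cc(-c3ccccc3O)n2)cc1` carries a thiophenyl group and a 4-hydroxyphenyl group on that core. In a functional assay on T47D cells (Homo sapiens) for cytotoxicity, read by CCK-8 assay (on this read-out lower numbers stand for stronger inhibition and higher numbers for weaker inhibition), compound 1 gives only a limit of the assay, > 50000 nM. Compound 2 `Oc1ccccc1-c1cc(-c2ccoc2)cc(-c2ccccc2O)n1` carries a furan-3-yl group and two 2-hydroxyphenyl groups. In this assay compound 2 likewise reaches only the limit, > 50000 nM. Compound 2 therefore stands at the limit of > 50000 nM in this assay, at which 2 of the 2 values shown sit, so nothing separates it from compound 1 on the numbers shown.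

Compound 3 `Oc1ccc(-c2cc(-c3ccoc3)cc(-c3ccccc3O)n2)cc1` has not yet been measured. It differs from compound 2 by 4-hydroxyphenyl in place of 2-hydroxyphenyl on an aromatic carbon, so that compound 3 carries the 4-hydroxyphenyl group that compound 1 also carries. Among the measured compounds shown here, no step between measured compounds exists here, so the size of this change cannot be read from the data. Compound 3 is expected to stay at the limit, because compound 1 with the same 4-hydroxyphenyl group gives > 50000 nM. The step from compound 2 to compound 3 is expected to be a step that the limit leaves unreadable from compound 2 to compound 3, none beyond the scatter. Compound 3 is estimated at 70000 nM, within 20000 nM to 250000 nM.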

Compound 3, half-maximal inhibitory concentration: > 50000 nM
Compound 3: a limit, no number; the forecaster's own chance of this, stated with the estimate: 80%; the middle value lies beyond the limit too.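

In this assay compound 3 gives > 50000 nM, which is a limit of the assay and not a number. The steps from compound 2 to compound 3 and from compound 1 to compound 3 therefore cannot be read: the limit of > 50000 nM in this assay, at which 3 of the 3 values shown sit.

The compounds shown leave open whether any change on the shared core would give a measurable value in this assay.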